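The compounds below may be only part of what the source reports. "The series", "measured", "known", "first", "only" and "open" are said of these compounds alone.

Compound 1 `Cc1oc(-c2ccc(Cl)cc2)nc1CN1CCC(C(=O)NCCCN2C[C@H](C)C[C@H](C)C2)CC1`: > 72 ug/mL
Compound 2 `COc1cccc(Br)c1-c1nc(CN2CCC(C(=O)NCCCN3C[C@H](C)C[C@H](C)C3)CC2)c(C)o1`: > 83 ug/mL

In a physicochemical assay for solubility, in phosphate buffer, measured as kinetic solubility, at pH 7.4 (a higher number here means a more soluble compound, a lower number a less soluble compound), compound 1 sits at the limit of > 72 ug/mL in this assay, at which 1 of the 2 values shown sits, so its value is a limit rather than a number. Compound 2 likewise sits at the limit of > 83 ug/mL in this assay, at which 1 of the 2 values shown sits, again a limit and not a number. The step that the two limits leave unreadable from compound 1 to compound 2 therefore cannot be sized. Compound 3 `COc1cccc(OC)c1-c1nc(CN2CCC(C(=O)NCCCN3C[C@H](C)C[C@H](C)C3)CC2)c(C)o1` differs from compound 2 by methoxy in place of bromo on an aromatic carbon. For the measured compounds named here, no measured step bears on this change, and with both neighbours at their limits no shift beyond the scatter is expected: the estimated step is a step that the limit leaves unreadable from compound 2 to compound 3. Compound 3 is expected at 100 ug/mL, within 60 ug/mL to 200 ug/mL, most likely reported again as a limit.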

Compound 3, solubility: > 76 ug/mL
Compound 3: no number, only a limit; the forecaster's own chance of this, stated with the estimate: 80%; the middle value is on the limit's open side.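

For the compounds shown here, compound 1, compound 2 and compound 3 each give only a limit, not a number, in this assay, so no step among them can be read. From the compounds shown here alone, how far these compounds lie apart in this assay remains open.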